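Swapping the Five-Membered Ring on a Nucleoside Core

The source may report more compounds than this note shows. Statements on the series, on what has been measured and on what is new or still open speak of the compounds shown alone.

Compound 1 `COc1ncnc2c1c(-c1ccsc1)cn2[C@@H]1O[C@H](CO)[C@@H](O)[C@H]1O`: 90 nM
Compound 2 `COc1ncnc2c1c(-c1ccoc1)cn2[C@@H]1O[C@H](CO)[C@@H](O)[C@H]1O`: 190 nM

In a functional assay on K562 cells (Homo sapiens), read by MTT assay, with a stated time of 72 h (on this read-out lower numbers stand for stronger inhibition and higher numbers for weaker inhibition), compound 2 gives the higher of the two numbers, and its nearest neighbour is compound 1 with 90 nM. Compound 3 `COc1ncnc2c1c(-c1cccs1)cn2[C@@H]1O[C@H](CO)[C@@H](O)[C@H]1O` differs from compound 2 by thiophen-2-yl in place of furan-3-yl on an aromatic carbon. Among the measured compounds shown here, the only measured step that bears on this is a 2.1-fold higher number from compound 1 to compound 2 (0.32 log units; beyond the scatter), which shows a sulfur ring outperforming an oxygen ring. Compound 3 brings sulfur back, though attached through a different ring carbon, so a step of about a 1.9-fold lower number from compound 2 to compound 3 (0.28 log units; within the scatter) downward is expected. Compound 3 is estimated at 100 nM, within 40 nM to 300 nM.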

Compound 3, half-maximal inhibitory concentration: 70 nM
Estimate against measurement, compound 3: 1.4-fold (0.15 log units) above; low and high end bracket the measured number.
By their numbers in this assay, from the lowest: compounds 3 and 1 (each within the scatter of the next); then compound 2.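

In this assay, moving the attachment point on the sulfur ring leaves a step of a 1.3-fold lower number from compound 1 to compound 3 (0.11 log units; within the scatter) and so no readable difference between thiophen-2-yl and thiophen-3-yl at this carbon. The change to thiophen-2-yl from furan-3-yl gives a 2.7-fold lower number from compound 2 to compound 3 (0.43 log units; beyond the scatter) and alters both the ring atom and the attachment point, leaving furan-3-yl with the highest number of the three. No evidence here explains these numbers.

Going by these compounds, whether furan-2-yl would match the thiophenes stays open. So does the outcome with a phenyl ring or an amine at this carbon.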